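Trading the Methoxy Chain for a Vinyl Group

A few compounds are considered here, and "the series" means these few. Any claim that something is new, unique, unknown or untested is made for them only; others in the source may bear on it.

Three amidines carrying the same aminobutyl tail have been examined in an assay on cells for inhibition of N(G),N(G)-dimethylarginine dimethylaminohydrolase 1 (Homo sapiens), with a stated time of 30 min; a higher number here means a weaker inhibitor, a lower number a stronger inhibitor. Compound 1 `COCC(=N)NCCCCN` gives 983000 nM. Compound 2 `COCCC(=N)NCCCCN` gives 1450000 nM. Compound 3 `COCCCC(=N)NCCCCN` extends the chain once more, yet for compound 3 this assay records "not determined" (no result reported), so its position on these numbers cannot be fixed; the two neighbours that were measured both sit in the very weak range, and the step of a 1.5-fold higher number from compound 1 to compound 2 (0.17 log units; within the scatter) shows that lengthening the chain by one carbon made no difference beyond the scatter.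

Compound 4 `C=CCC(=N)NCCCCN` departs from compound 3 by the change (vinyl in place of 2-methoxyethyl on a saturated chain carbon bound to a carbon with a double bond to nitrogen). For the measured compounds named here, no measured pair mirrors this exchange, so the only guidance is indirect: the step from compound 1 to compound 2 bears on it merely by showing that small edits to this side chain left this assay essentially unmoved. On that basis no shift beyond the scatter is expected, though the removal of the oxygen-bearing chain is a larger change than any measured here, and the uncertainty is accordingly wide. Compound 4 is therefore expected to give about 500000 nM, with a range from 100000 nM to 2500000 nM.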

Compound 4, inhibition constant: 768000 nM
Compound 4: the middle estimate sits 1.5-fold (0.19 log units) below what was measured; the range from low to high includes it.
By their numbers in this assay, from the lowest: compounds 4, 1 and 2 (each within the scatter of the next).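

In this assay, vinyl on a saturated chain carbon bound to a carbon with a double bond to nitrogen gives a 1.9-fold lower number from compound 2 to compound 4 (0.28 log units; within the scatter) and a 1.3-fold lower number from compound 1 to compound 4 (0.11 log units; within the scatter). Every side chain measured before compound 4 held an oxygen, whereas the vinyl group holds none, so this result adds that, among these three measured compounds, a side chain without oxygen stands within the scatter of those with it, and the whole set stays in the very weak range. Nothing available bears on why the exchange leaves the number so little moved.

The step from compound 3 to compound 4 cannot be read, as compound 3 has no result to compare, so the exchange that replaces 2-methoxyethyl with vinyl remains without a direct measure. The compounds shown leave open whether an amine, a carboxylic acid or a phenyl ring at this place would bring the number out of the very weak range, and whether a longer chain in place of the aminobutyl tail would do so.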